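Swapping diethylamino for dimethylamino in compound 2

The source may report more compounds than this note shows. Statements on the series, on what has been measured and on what is new or still open speak of the compounds shown alone.

In a functional assay on NCI-H460 cells (Homo sapiens) for cytotoxicity, read by MTT assay, with a stated time of 72 h (on this read-out higher numbers stand for weaker inhibition and lower numbers for stronger inhibition), compound 1 (`CCN(CC)Cc1ccc2nc(NC(=O)N/N=C/c3cn(Cc4ccc(Cl)cc4Cl)c4ccccc34)sc2c1`) reads 1080 nM while compound 2 (`CCN(CC)Cc1ccc2nc(NC(=O)N/N=C/c3cn(Cc4cccc(Cl)c4)c4ccccc34)sc2c1`) reads 220 nM and compound 3 (`CCN(CC)Cc1ccc2nc(NC(=O)N/N=C/c3cn(Cc4ccc(C)cc4)c4ccccc34)sc2c1`) reads 320 nM on the same scale. Compound 2 therefore sits at the low end of these numbers, level with compound 3 within the scatter and clearly under compound 1. Compound 4 (`CN(C)Cc1ccc2nc(NC(=O)N/N=C/c3cn(Cc4cccc(Cl)c4)c4ccccc34)sc2c1`) keeps all of compound 2 except one group, with dimethylamino in place of diethylamino on a saturated chain carbon bound to an aromatic carbon. Among the compounds with values here, no measured step touches this group. The available steps all change the substituted phenyl group instead: a 4.9-fold lower number from compound 1 to compound 2 (0.69 log units; beyond the scatter) and a 3.4-fold lower number from compound 1 to compound 3 (0.53 log units; beyond the scatter) are modest, and a 1.5-fold higher number from compound 2 to compound 3 (0.16 log units; within the scatter) stays within the scatter. They show only how far the numbers moved for a change elsewhere, so no step beyond the scatter is expected in this assay for this small trim, though the data cannot rule one out. The estimate amounts to a 1.2-fold higher number from compound 2 to compound 4 (0.07 log units; within the scatter) as the expected step. Compound 4 is estimated at 260 nM with 110 nM to 600 nM as its expected range.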

Compound 4, half-maximal inhibitory concentration: 420 nM
For compound 4 the middle estimate is 1.6-fold (0.21 log units) below the measured one; measured number inside the range.
By their numbers in this assay, from the lowest: compounds 2, 3 and 4 (each within the scatter of the next); then compound 1.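

In this assay the amine end of the molecule now has a measured step of its own, which the earlier changes to the substituted phenyl group could not provide: dimethylamino in place of diethylamino gives a 1.9-fold higher number from compound 2 to compound 4 (0.28 log units; within the scatter) and so the two compounds cannot be told apart on this read-out. With the 3-chlorophenyl group held fixed, this single pair shows that the smaller amine serves as well as the larger one. No measurement available here explains this outcome.

Still open, on these data alone, is whether a ring amine such as morpholine or pyrrolidine, or a longer chain such as dipropylamino, would also stay level at this place. As far as these compounds go, it is equally open whether the same trim would read alike with the 2,4-dichlorophenyl or 4-methylphenyl group in the molecule.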